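The source may report more compounds than this note shows. Statements on the series, on what has been measured and on what is new or still open speak of the compounds shown alone.

Three hydroxamic acids have been measured in an assay on Sf9 cells for inhibition of protein deacetylase HDAC6 (Homo sapiens), read by fluorescence; a higher number here means a weaker inhibitor, a lower number a stronger inhibitor. Compound 1 `Cc1ccc(C(=O)NO)cc1F` gives 49 nM, the lowest of the three numbers. Compound 3 `Nc1ncc(C(=O)NO)cn1` gives 64 nM, a number that lies within the scatter of compound 1. Compound 2 `O=C(NO)c1cccnc1` gives 679 nM, a clearly higher number than compound 1, beyond the scatter.

The next compound, compound 4 `Nc1ccc(C(=O)NO)cc1F`, differs from compound 1 in one place: amino in place of methyl on an aromatic carbon. For the measured compounds named here, no step between two measured compounds shows what such a swap does in this assay. Going by the values given here, with the hydroxamic acid kept and only this small group exchanged, the step of a 1.4-fold higher number from compound 1 to compound 4 (0.15 log units; within the scatter) is expected to stay close to the scatter, with a slight lean toward a higher number. Compound 4 is therefore estimated at 70 nM, between 25 nM and 200 nM.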

Compound 4, half-maximal inhibitory concentration: 183 nM
Estimate against measurement, compound 4: 2.6-fold (0.42 log units) below; low and high end bracket the measured number.
By their numbers in this assay, from the lowest: compounds 1 and 3 (each within the scatter of the next); then compound 4; then compound 2.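

In this assay, amino in place of methyl on the aromatic carbon ortho to the fluoro group and para to the hydroxycarbamoyl group gives a 3.7-fold higher number from compound 1 to compound 4 (0.57 log units; beyond the scatter). This position therefore responds to a swap of one heavy atom for another, even with the hydroxamic acid kept, and the response is modest. No measurement here explains why the number rises.

From the compounds shown here alone, whether a hydroxyl, a methoxy or a chlorine here would sit nearer compound 1 or compound 4 stays open. So does whether the same swap has a similar effect without the fluoro group.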